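Swapping Fluoro for Methoxycarbonyl in a Cytotoxicity Series

The source may report more compounds than this note shows. Statements on the series, on what has been measured and on what is new or still open speak of the compounds shown alone.

Compound 1, `CCc1ccc(-c2nc3c(c(C)nn3-c3ccccc3)c(-c3ccccc3O)c2C#N)cc1`, carries a hydroxy group on the phenyl ring that hangs from the shared core. In an ADME assay on BJ cells (Homo sapiens) for cytotoxicity, with a stated time of 72 h (on this read-out higher numbers stand for an effect only at larger amounts of compound and lower numbers for an effect already at smaller amounts), compound 1 gives > 20000 nM, which is a limit of the assay rather than a number. Compound 2, `CCc1ccc(-c2nc3c(c(C)nn3-c3ccccc3)c(-c3ccccc3F)c2C#N)cc1`, carries fluoro in place of that hydroxy. In this assay compound 2 gives > 20000 nM, again a limit and not a measured number. The step that the two limits leave unreadable from compound 1 to compound 2 therefore cannot be read. For the measured compounds named here, compound 2 thus stands at the limit, as does the only other value shown, and the limit of > 20000 nM in this assay, at which 2 of the 2 values shown sit, is the whole of the evidence. Compound 3, `CCc1ccc(-c2nc3c(c(C)nn3-c3ccccc3)c(-c3ccccc3C(=O)OC)c2C#N)cc1`, is not yet measured; it differs from compound 2 by methoxycarbonyl in place of fluoro on an aromatic carbon. Going by the values given here, no measured step bears on this change, since the one step available is unreadable. With both values at the limit and no readable step, no direction of change can be expected in this assay. Compound 3 is therefore estimated to give 25000 nM, with a range from 8000 nM to 80000 nM. The step this estimate means, a step that the limit leaves unreadable from compound 2 to compound 3, is expected to be none beyond the scatter, and the assay is expected most likely to report only a limit once more.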

Compound 3, half-maximal effective concentration: > 20000 nM
Compound 3 ended at the assay's limit (the forecaster's own chance of this, stated with the estimate: 80%); the middle value is on the limit's open side.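

In this assay compound 3 gives > 20000 nM and this is a limit, not a number. For the compounds shown here, no step among compound 1, compound 2 and compound 3 can therefore be read. These compounds leave open whether any group at this place on the aromatic ring would produce a measurable effect. What stands is only this: the limit of > 20000 nM in this assay, at which 3 of the 3 values shown sit.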